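Pyridinecarbonyl hydrazide replaces phthalazinylhydrazine on compound 2

This account rests on a few compounds, and the source may have more. Where it says the series, first, only, none or still open, it means among the compounds named here.

Compound 1, `CCOc1ccc(C2CC2C(=O)NNC(=O)c2ccncc2)cc1`, carries an ethoxy group and a pyridinecarbonyl hydrazide. In a functional assay on PC-3 cells (Homo sapiens) for inhibition, read by MTT assay, with a stated time of 72 h (a higher number here means a weaker inhibitor, a lower number a stronger inhibitor), compound 1 reaches only the limit > 100000 nM, no number. Among the measured compounds shown here, compound 2, `CC(C)=CCC/C(C)=C/COc1ccc(C2CC2C(=O)NNc2nncc3ccccc23)cc1`, carries the longer geranyl-type ether and a phthalazinyl hydrazine; in this assay compound 2 gives 24000 nM, the only actual number. Compound 1 alone stands at the limit (the limit of > 100000 nM in this assay, at which 1 of the 2 values shown sits). Compound 3, `CC(C)=CCC/C(C)=C/COc1ccc(C2CC2C(=O)NNC(=O)c2ccncc2)cc1`, keeps the ether of compound 2 and differs by a group of 8 heavy atoms (6 carbon, 1 nitrogen, 1 oxygen; one six-membered aromatic ring with 1 hetero atom) in place of a group of 10 heavy atoms (8 carbon, 2 nitrogen; one six-membered aromatic ring of carbon only, one six-membered aromatic ring with 2 hetero atoms), on an amine nitrogen. No measured step covers this exchange, so the expectation rests on the series as shown: compound 1 also carries the pyridinecarbonyl hydrazide and sits at the limit. From compound 2 to compound 3 a loss of potency beyond the scatter is expected, a 2.5-fold higher number from compound 2 to compound 3 (0.40 log units; beyond the scatter). Compound 3 is accordingly estimated at 60000 nM, between 20000 nM and 200000 nM, with a real chance that this assay reports only a limit.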

Compound 3, half-maximal inhibitory concentration: > 100000 nM
Compound 3 ended at the assay's limit; the forecaster's own chance of this, stated with the estimate: 45%; at least 1.6-fold (0.22 log units) between middle value and limit.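

With the geranyl-type ether held fixed, (pyridin-4-yl)carbonyl on the amine nitrogen in place of the phthalazinyl group gives an at least 4.1-fold higher number from compound 2 to compound 3 (0.61 log units; beyond the scatter) in this assay. Among the compounds shown here, compound 1 differs from compound 2 in both the ether and this group, so only the pair of compound 2 and compound 3 isolates the exchange on the amine nitrogen, and the loss there is beyond the scatter, with its full size hidden by a limit. The ether exchange from compound 1 to compound 3 cannot be read, as the values on both sides are limits: the limit of > 100000 nM in this assay, at which 2 of the 3 values shown sit.

Whether the ether affects potency when the phthalazinyl group is present remains open, as an ethoxy partner for compound 2 is not among the compounds shown. Also open is how a benzoyl group on the same nitrogen would compare with the two groups shown here.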